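The compounds below may be only part of what the source reports. "The series", "measured", "known", "first", "only" and "open" are said of these compounds alone.

Of the compounds shown here, two carry numbers so far. In a functional assay on G-361 cells (Homo sapiens) for antiproliferative activity, with a stated time of 72 h (on this read-out lower numbers stand for stronger inhibition and higher numbers for weaker inhibition), compound 1 (`OC[C@H]1O[C@@H](n2cnc3c(NCc4ccc(Cl)c(Cl)c4)ncnc32)[C@H](O)[C@@H]1O`) gives 145000 nM as its reading, while compound 2 (`OC[C@H]1O[C@@H](n2cnc3c(NCc4cccc(O)c4O)ncnc32)[C@H](O)[C@@H]1O`) gives 16900 nM as the lower of the two numbers. Among the measured compounds shown here, the only measured step, an 8.6-fold lower number from compound 1 to compound 2 (0.93 log units; beyond the scatter) on exchanging 3,4-dichlorophenyl for 2,3-dihydroxyphenyl, replaces the whole substitution pattern. Compound 3 (`Cc1cccc(CNc2ncnc3c2ncn3[C@@H]2O[C@H](CO)[C@@H](O)[C@H]2O)c1O`) is reached through methyl in place of hydroxy on an aromatic carbon at one position, turning 2,3-dihydroxybenzyl into 2-hydroxy-3-methylbenzyl. For the measured compounds named here, no measured pair isolates this exchange of hydroxy for methyl, so the step from compound 1 offers only a rough upper guide to size. A change of one group should stay smaller than that step, and no clear direction can be drawn from the data. The expected move is a 1.1-fold lower number from compound 2 to compound 3 (0.05 log units; within the scatter) and is not expected to exceed the scatter clearly. Compound 3 is estimated at 15000 nM with an expected range from 4000 nM to 60000 nM in this assay for now.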

Compound 3, half-maximal inhibitory concentration: > 166000 nM
Compound 3: a limit, no number; the forecaster's own chance of this, stated with the estimate: 15%; at least 11-fold (1.04 log units) between middle value and limit.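

In this assay compound 3 carries a limit and not a number: the limit of > 166000 nM in this assay, at which 1 of the 3 values shown sits.

Methyl in place of hydroxy on this aromatic carbon, ortho to a hydroxy group, gives an at least 9.8-fold higher number from compound 2 to compound 3 (0.99 log units; beyond the scatter), so one exchanged group here moves the reading by an amount comparable to the change of the whole substitution pattern in an 8.6-fold lower number from compound 1 to compound 2 (0.93 log units; beyond the scatter). The exchange of 3,4-dichlorophenyl for 2-hydroxy-3-methylphenyl reads only as an at least 1.1-fold higher number from compound 1 to compound 3 (0.05 log units; that floor lies within the scatter), so the lower number seen with 2,3-dihydroxyphenyl does not persist once methyl replaces that hydroxy, and this floor sets no order.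

The compounds shown do not tell whether an amine or a methoxy group on this carbon would keep the reading of compound 2. Going by these compounds, what the 2-hydroxy group contributes on its own also stays open, as does the true size of the step to compound 3.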